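A few compounds are considered here, and "the series" means these few. Any claim that something is new, unique, unknown or untested is made for them only; others in the source may bear on it.

Compound 1 `O=S(=O)(c1cc(Cl)cc(Cl)c1)c1cnc2c(F)cccc2c1-c1ccc(F)cc1` gives 1.01 mL/min, compound 2 `O=S(=O)(c1ccc(F)c(F)c1)c1cnc2c(F)cccc2c1-c1ccc(F)cc1` gives 0.78 mL/min, and compound 3 `COc1ccc(-c2c(S(=O)(=O)c3cccc(F)c3)cnc3c(F)cccc23)cc1` gives 2.48 mL/min in an ADME assay on microsomes from liver (Homo sapiens) for metabolic stability, tested at 2.5 uM; on this read-out higher numbers stand for fast clearance and lower numbers for slow clearance.

Compound 3 stands at the highest of the three numbers, beyond the scatter from compound 1 and from compound 2. Among the measured compounds shown here, the one measured step, a 1.3-fold lower number from compound 1 to compound 2 (0.11 log units; within the scatter), sits on the aryl of the sulfonyl sulfur and is within the scatter, so it does not bear directly on the change to come. Compound 4 `O=S(=O)(c1cccc(F)c1)c1cnc2c(F)cccc2c1-c1ccc(F)cc1` differs from compound 3 in that (fluoro in place of methoxy on an aromatic carbon). Compound 1 and compound 2 already carry this 4-fluorophenyl. Compound 4 is therefore expected to give 1 mL/min, in the range 0.5 mL/min to 2 mL/min. The expected step, a 2.5-fold lower number from compound 3 to compound 4 (0.39 log units; beyond the scatter), is estimated as a lower number because compound 1 gives 1.01 mL/min and compound 2 gives 0.78 mL/min.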

Compound 4, intrinsic clearance in a liver preparation (reported as CLH), per the amount of preparation that the assay uses: 0.19 mL/min
Estimate against measurement, compound 4: 5.3-fold (0.72 log units) above; measured number below the stated range.
By their numbers in this assay, from the lowest: compound 4; then compounds 2 and 1 (each within the scatter of the next); then compound 3.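

In this assay the change from 4-methoxyphenyl to 4-fluorophenyl gives a 13-fold lower number from compound 3 to compound 4 (1.12 log units; beyond the scatter) and is a large step at this position. Among the compounds shown here, the aryl on the sulfonyl sulfur, where the one earlier step stayed within the scatter, now also moves the number, with a 4.1-fold lower number from compound 2 to compound 4 (0.61 log units; beyond the scatter) and a 5.3-fold lower number from compound 1 to compound 4 (0.73 log units; beyond the scatter) both ending at the 3-fluorophenyl. Nothing measured here gives a cause for these steps. Going by these compounds, whether an amine or a chloro in place of the fluoro would keep the number as low stays open, as does whether the same change holds with the other aryls on the sulfonyl sulfur.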